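This account rests on a few compounds, and the source may have more. Where it says the series, first, only, none or still open, it means among the compounds named here.

Measured in an assay on SH-EP1 cells for agonist activity at Neuronal acetylcholine receptor; alpha4/beta2 (Homo sapiens), read by FLIPR and calcium flux; on this read-out lower numbers stand for an effect already at smaller amounts and higher numbers for an effect only at larger amounts of compound:
- compound 1 `CC(=O)N1CC2CC(C1)N2` gives 5100 nM
- compound 2 `O=C(C1CCCC1)N1CC2CC(C1)N2` gives 11000 nM
- compound 3 `O=C(C1CC=CC1)N1CC2CC(C1)N2` gives 6600 nM

All three share the same bicyclic amide core and differ only in the acyl group. Compound 1 stands at the lowest of the three numbers, but its gap to compound 3 is within the usual scatter, so no order between those two can be read from the data; only the gap to compound 2 lies beyond the scatter.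

Compound 4 `O=C(CC1C=CCC1)N1CC2CC(C1)N2` has not yet been measured. Relative to compound 1 the change is cyclopent-2-en-1-yl in place of hydrogen on a saturated chain carbon bound to a carbonyl carbon. For the measured compounds named here, no pair of measured compounds shows this kind of change, so there is no step to lean on. The closest information is that compound 2 and compound 3, which carry five-membered rings directly on the carbonyl, do not give numbers below that of compound 1.

The expectation for compound 4 in this assay is therefore a step from compound 1 of a 1.5-fold higher number from compound 1 to compound 4 (0.17 log units; within the scatter), a small move towards larger amounts or none beyond the scatter. The estimate for compound 4 is 7500 nM, with a range from 2500 nM to 22000 nM.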

Compound 4, half-maximal effective concentration: 14000 nM
Compound 4: middle estimate off by 1.9-fold (0.27 log units), on the low side, within the range that was stated.
By their numbers in this assay, from the lowest: compounds 1, 3, 2 and 4 (each within the scatter of the next, the first and the last beyond it).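

In this assay, cyclopent-2-en-1-yl in place of hydrogen on a saturated chain carbon bound to a carbonyl carbon gives a 2.7-fold higher number from compound 1 to compound 4 (0.44 log units; beyond the scatter). For the compounds shown here, this is the first step that isolates a change in one place, and it shows that this substitution on the chain carbon moves the effect towards larger amounts of compound by more than the usual scatter. No available measurement accounts for the shift.

From the compounds shown here alone, whether the step comes from the ring, its double bond or simply from any carbon group on this chain carbon stays open. Also open, going by these compounds, is how an amine, a carboxylic acid or a longer open chain in the same place would read, and whether any group there can bring the number under that of compound 1.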